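From 4-methoxyphenyl to a smaller ring at the limit

The source may hold more compounds than are shown below. What is called first, only, known or untested is meant among the compounds shown, and "the series" means these compounds.

compound 1 `O=C(Nc1ccccn1)c1cc(=O)[nH]c2cc(Br)ccc12`: 11000 nM
compound 2 `CC(=O)c1ccc(-c2ccc3c(C(=O)Nc4cccc(F)c4)cc(=O)[nH]c3c2)cc1`: > 20000 nM
compound 3 `COc1ccc(-c2ccc3c(C(=O)Nc4cccc(F)c4)cc(=O)[nH]c3c2)cc1`: > 20000 nM

All three compounds were tested in a functional assay on KYSE-70 cells for antiproliferative activity against KYSE-70 cell line (Homo sapiens), read by MTT assay, with a stated time of 72 h; on this read-out lower numbers stand for stronger inhibition and higher numbers for weaker inhibition. Among the measured compounds shown here, compound 1 gives 11000 nM, the only true number so far. Compound 2 gives > 20000 nM, which is a limit of the assay and not a number. Compound 3 gives > 20000 nM, also a limit. On these data alone, compound 3 therefore stands at the limit of > 20000 nM in this assay, at which 2 of the 3 values shown sit, so its real position is unknown.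

Compound 4 `O=C(Nc1cccc(F)c1)c1cc(=O)[nH]c2cc(C3=CCOCC3)ccc12` has not yet been measured. It differs from compound 3 at a single place, on an aromatic carbon: a group of 6 heavy atoms (5 carbon, 1 oxygen; one six-membered non-aromatic ring with 1 hetero atom) in place of a group of 8 heavy atoms (7 carbon, 1 oxygen; one six-membered aromatic ring of carbon only), on an aromatic carbon.

For the measured compounds named here, only one measured step offers guidance: a step that the two limits leave unreadable from compound 2 to compound 3. That step swaps a group on the aromatic ring that leaves in compound 4, and it provides no size to carry over. With no readable step to build on, no clear direction can be expected in this assay. The best expectation is that compound 4 stays close to the limit seen for compound 3, and another report of only a limit would be no surprise. The expected change is a number no higher from compound 3 to compound 4 (the limit leaves the size open). Compound 4 is estimated at 20000 nM, with an expected range from 9000 nM to 40000 nM.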

Compound 4, half-maximal inhibitory concentration: 10500 nM
The estimate for compound 4 lay 1.9-fold (0.28 log units) above the measured number, within the range that was stated.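

In this assay, compound 4 gives 10500 nM, the first true number among the compounds shown that share this amide and carry a ring at this aromatic carbon, so a non-aromatic ring with one oxygen can sit here and still give a readable value. Putting that ring in place of the 4-methoxyphenyl gives an at least 1.9-fold lower number from compound 3 to compound 4 (0.27 log units; that floor lies within the scatter), and putting it in place of the acetyl-bearing aromatic ring gives an at least 1.9-fold lower number from compound 2 to compound 4 (0.27 log units; that floor lies within the scatter); each is only a floor, so the real steps could be larger or could stay small. Compound 2 and compound 3 each stand at a limit of the assay and not a number, so the step between them cannot be read: the limit of > 20000 nM in this assay, at which 2 of the 4 values shown sit.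

On these data alone, what the ring's double bond and its oxygen each add stays open, as does how a piperidine ring, with nitrogen in place of the oxygen, or a carboxylic acid at this place would read. With only one true value among these compounds, no trend across groups at this aromatic carbon can yet be drawn.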